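A few compounds are considered here, and "the series" means these few. Any claim that something is new, unique, unknown or untested is made for them only; others in the source may bear on it.

Measured compounds:
- compound 1 `N=C1S/C(=C\c2ccc(OCc3ccccc3)cc2)C(=O)N1c1ccc(Cl)cc1`: 16.4%
- compound 2 `N=C1S/C(=C\c2ccc(OCc3ccccc3)cc2)C(=O)N1c1ccccc1[N+](=O)[O-]`: 24.4%

In an ADME assay on RAW264.7 cells (Mus musculus) for cytotoxicity, read by MTT assay, with a stated time of 48 h, tested at 50 uM (a higher number here means more inhibition at the concentration tested (going by the name of the read-out), a lower number less inhibition), compound 1 gives 16.4%, and compound 2 gives 24.4%. Among the measured compounds shown here, of the two numbers, that of compound 2 is the larger, but the only measured step, a number 8 percentage points higher from compound 1 to compound 2 (within the scatter), is a difference that repeated measurements could produce on their own, so the two compounds cannot be told apart on these data.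

Compound 3 `N=C1S/C(=C\c2ccc(OCc3ccccc3)cc2)C(=O)N1c1cccc([N+](=O)[O-])c1` differs from compound 2 in one place: 3-nitrophenyl in place of 2-nitrophenyl on an amide-type nitrogen in a ring. The step from compound 1 to compound 2 is the only one that bears on this, since it also swapped the group on that ring nitrogen, and it stayed within the scatter. On that basis no step beyond the scatter is expected in this assay for compound 3, and its value is estimated at 22%, with a range from 8% to 38%, which means an expected step of a number 2.4 percentage points lower from compound 2 to compound 3 (within the scatter).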

Compound 3, a percentage reported as inhibition, at one concentration (the size of the read-out at that concentration, not a potency): 52.9%
Estimate against measurement, compound 3: 30.9 percentage points below, and the stated range ends below it.
By their numbers in this assay, from the lowest: compounds 1 and 2 (each within the scatter of the next); then compound 3.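

In this assay, the place of the nitro group on the phenyl ring matters: 3-nitrophenyl in place of 2-nitrophenyl gives a number 28.5 percentage points higher from compound 2 to compound 3 (beyond the scatter) even though the two compounds hold the same atoms, joined differently. The change from 4-chlorophenyl to 3-nitrophenyl on the same amide-type nitrogen gives a number 36.5 percentage points higher from compound 1 to compound 3 (beyond the scatter) and so also lies beyond the scatter, which shows that the group at this position can move the reading clearly, something the earlier pair of compounds could not show. Nothing at hand explains why 3-nitrophenyl reads higher here.

Going by these compounds, whether 4-nitrophenyl would read like 3-nitrophenyl or like 2-nitrophenyl remains open. So does what an amine or a carboxylic acid in place of the nitro group would do, and whether this effect would hold at other concentrations.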